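The source may report more compounds than this note shows. Statements on the series, on what has been measured and on what is new or still open speak of the compounds shown alone.

Two compounds of this series have so far been run through a functional assay on the whole organism for inhibition, with Mus musculus as the target, at a dose of 100 mg/kg by the oral route; on this read-out higher numbers stand for more inhibition at the one dose given (going by the name of the read-out) and lower numbers for less inhibition. Compound 1 `CCc1ccc2c(c1)CC=C(c1ccccc1)C(N1CCN(CC)CC1)=N2` gives 51% in this assay. Compound 2 `CC(C)c1ccc2c(c1)CC=C(c1ccccc1)C(N1CCN(C)CC1)=N2` gives 51% in this assay, level with compound 1 at the digits reported and within the scatter of it; the two differ from each other in more than one place, so their values are set side by side without a computed step between them. Compound 3 `COc1ccc2c(c1)CC=C(c1ccccc1)C(N1CCN(C)CC1)=N2` has not yet been measured in this assay. Relative to compound 2 the change is methoxy in place of isopropyl on an aromatic carbon. For the measured compounds named here, no pair among the measured compounds isolates a change of this kind, so nothing in the data to hand says in which direction such a substitution moves the read-out. With the two measured compounds sitting at the same level, the expectation for compound 3 is a step from compound 2 that stays within the scatter, a number 5 percentage points lower from compound 2 to compound 3 (within the scatter). Compound 3 is estimated at 46% in this assay, with a range from 20% to 70%.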

Compound 3, a percentage reported as inhibition, in the whole organism at one dose (the size of the read-out at that dose, not a potency): 51%
Compound 3: the middle estimate sits 5 percentage points below what was measured, within the range that was stated.
By their numbers in this assay, from the lowest: compounds 1, 2 and 3 (each within the scatter of the next).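

In this assay the series now has its first pair differing in one place, and methoxy in place of isopropyl on an aromatic carbon, meta to a fused ring and para to a fused ring, gives no change at the digits printed from compound 2 to compound 3 (within the scatter). At this position, the read-out at the one dose therefore does not separate the all-carbon isopropyl, with its three heavy atoms, from the methoxy, with two heavy atoms including an oxygen and one hydrogen-bond acceptor. No supporting data bear on why these two groups read alike.

The compounds shown leave open whether this position responds to groups of another kind, such as an amine, a carboxylic acid or a longer chain, as only isopropyl and methoxy are compared here in a single matched pair. This one pair also cannot tell whether the same swap would read alike where the rest of the molecule differs, as it does in compound 1.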